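This account rests on a few compounds, and the source may have more. Where it says the series, first, only, none or still open, it means among the compounds named here.

Two measured compounds set the frame here. Compound 1 `O=C(CBr)Nc1ccc(C(=O)/C=C/c2ccco2)cc1` carries a furan-2-yl ring, while compound 2 `O=C(CO[N+](=O)[O-])Nc1ccc(C(=O)/C=C/c2ccc(Cl)cc2)cc1` carries a 4-chlorophenyl ring and a nitrooxy group in its side chain. In a functional assay on the whole organism (strain albino) for inhibition, with Rattus norvegicus as the target, read by paw edema, with stated times of 30 min and 2 h, at a dose of 100 mg/kg by the oral route (on this read-out higher numbers stand for more inhibition at the one dose given (going by the name of the read-out) and lower numbers for less inhibition), compound 1 gives 37%, and compound 2 gives 57%, the higher of the two numbers, standing above compound 1 by a gap beyond the usual scatter. Among the compounds with values here, as the two compounds differ in more than one place, no single step between them can be drawn. Compound 3 `O=C(CO[N+](=O)[O-])Nc1ccc(C(=O)/C=C/c2ccco2)cc1` has not yet been measured; it differs from compound 2 by furan-2-yl in place of 4-chlorophenyl on a double-bonded chain carbon bound to a double-bonded chain carbon. Within the data shown here, because compound 1, the one measured compound that carries furan-2-yl, gives 37%, a modest downward step is expected, on the order of a number 11 percentage points lower from compound 2 to compound 3 (beyond the scatter). Compound 3 is therefore estimated to give 46%, within a range from 32% to 60%.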

Compound 3, a percentage reported as inhibition, in the whole organism at one dose (the size of the read-out at that dose, not a potency): 36%
Compound 3: middle estimate off by 10 percentage points, on the high side; the measured number falls inside the stated range.
By their numbers in this assay, from the lowest: compounds 3 and 1 (each within the scatter of the next); then compound 2.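

Within the data shown here, for the first time, the two changes can be read apart. In this assay, with the nitrooxy side chain held fixed, putting furan-2-yl in place of 4-chlorophenyl gives a number 21 percentage points lower from compound 2 to compound 3 (beyond the scatter), so the group at this place on the double-bonded chain carbon matters to the read-out. With furan-2-yl held fixed, putting nitrooxy in place of bromo on the saturated chain carbon gives a number 1 percentage points lower from compound 1 to compound 3 (within the scatter), so this swap shows no clear effect in the furan-2-yl compounds, and no measurement available here explains either step.

On these data alone, whether the side-chain swap would be equally silent alongside 4-chlorophenyl stays open. So does what an unsubstituted phenyl ring at the first place, or an amine on the saturated chain carbon, would give.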